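From Methylamino to Trifluoromethyl on the Shared Core

A few compounds are considered here, and "the series" means these few. Any claim that something is new, unique, unknown or untested is made for them only; others in the source may bear on it.

In a physicochemical assay for lipophilicity (on this read-out lower numbers stand for lower lipophilicity and higher numbers for higher lipophilicity), compound 3 `CNc1cc(-c2noc([C@H](C)NC(=O)c3cc(C(F)(F)F)nn3C)n2)ccn1` gives 3.4. This places it level with compound 2 `C[C@H](NC(=O)c1cc(C(F)(F)F)nn1C)c1nc(-c2ccnc(C(F)F)c2)no1` at 3.4, and the two share the low end of the three measured numbers, while compound 1 `C[C@H](NC(=O)c1cc(C(F)(F)F)nn1C)c1nc(-c2ccnc(N3CCCC3)c2)no1` stands apart at 4.2.

The unmeasured compound 4 `C[C@H](NC(=O)c1cc(C(F)(F)F)nn1C)c1nc(-c2ccnc(C(F)(F)F)c2)no1` keeps the shared core and differs from compound 3 at one place: trifluoromethyl in place of methylamino on an aromatic carbon. Trifluoromethyl stands in place of methylamino on an aromatic carbon, next to the ring nitrogen and meta to a large group.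

All three measured steps concern this same place. Difluoromethyl in place of pyrrolidin-1-yl gave a number 0.80 log units lower from compound 1 to compound 2 (beyond the scatter), and methylamino in place of pyrrolidin-1-yl gave a number 0.80 log units lower from compound 1 to compound 3 (beyond the scatter). Methylamino in place of difluoromethyl gave no change at the digits printed from compound 2 to compound 3 (within the scatter). Among the measured groups, difluoromethyl in compound 2 is the closest to trifluoromethyl, but no measured step tests trifluoromethyl itself, so the size of the change remains uncertain.

These steps show that this place can shift the number modestly, and a modest rise in this assay is expected here. The expected change is a number 0.50 log units higher from compound 3 to compound 4 (beyond the scatter). Compound 4 is estimated at 3.9, with an expected range from 3.5 to 4.3.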

Compound 4, distribution coefficient: 3.6
Estimate against measurement, compound 4: 0.30 log units above; measured number inside the range.
By their numbers in this assay, from the lowest: compounds 2, 3 and 4 (each within the scatter of the next); then compound 1.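

In this assay trifluoromethyl in place of methylamino gives a number 0.20 log units higher from compound 3 to compound 4 (within the scatter) and a third fluorine on the difluoromethyl carbon gives a number 0.20 log units higher from compound 2 to compound 4 (within the scatter) on the same aromatic carbon next to the ring nitrogen. At this place, then, methylamino with its one hydrogen-bond donor and one acceptor and trifluoromethyl with neither cannot be told apart on this read-out, and the third fluorine cannot be told from hydrogen. Pyrrolidin-1-yl remains the one group here that stands apart, since trifluoromethyl in its place gives a number 0.60 log units lower from compound 1 to compound 4 (beyond the scatter) in this assay, and nothing shown here gives a reason for any of these steps.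

The compounds shown leave open whether the separation of pyrrolidin-1-yl belongs to its ring or simply to its carbon count, which an open-chain amine such as diethylamino could begin to tell apart. They also leave open how far the number at this place would move with a group of another kind, such as a carboxylic acid or a nitrile.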